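The compounds below may be only part of what the source reports. "The series", "measured", "known", "first", "only" and "open" are said of these compounds alone.

Measured so far:
Compound 1 `CCCCCCCCCCCC[C@@H](O)[C@H]1CC[C@H]([C@H](O)CCCCCCCCCCNC(=O)c2ccoc2)O1`: 100000 nM
Compound 2 `CCCCCCCCCCCC[C@@H](O)[C@H]1CC[C@H]([C@H](O)CCCCCCCCCCNC(=O)c2cncs2)O1`: 100000 nM

In a functional assay on OVCAR-3 cells (Homo sapiens) for inhibition, read by colorimetric assay and sulforhodamine B assay, with a stated time of 48 h (on this read-out higher numbers stand for weaker inhibition of growth and lower numbers for stronger inhibition of growth), compound 2 gives 100000 nM, level with compound 1 at 100000 nM. Neither compound therefore stands apart from the other on these numbers.

Compound 3 `CCCCCCCCCCCC[C@@H](O)[C@H]1CC[C@H]([C@H](O)CCCCCCCCCCNC(=O)c2ccsc2)O1` keeps the shared core and changes only the ring on the carbonyl carbon, where thiophen-3-yl takes the place of 1,3-thiazol-5-yl: thiophen-3-yl in place of 1,3-thiazol-5-yl on a carbonyl carbon.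

Going by the values given here, only one measured step bears on this change. It sits at the same place and puts 1,3-thiazol-5-yl in place of furan-3-yl: no change at the digits printed from compound 1 to compound 2 (within the scatter). Among the compounds with values here, a single step is thin evidence, and no measured compound here shows how far a change at this place can move the read-out.

Given no change at the digits printed from compound 1 to compound 2 (within the scatter), a swap of one five-membered aromatic ring for another on a carbonyl carbon, the expected no change at the digits printed from compound 2 to compound 3 (within the scatter) stays within the scatter, with neither direction favoured.

The estimate for compound 3 in this assay is 100000 nM, with an expected range of 40000 nM to 150000 nM.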

Compound 3, concentration for 50% growth inhibition: 1700 nM
For compound 3 the middle estimate is 59-fold (1.77 log units) above the measured one, outside the stated range (below it).
By their numbers in this assay, from the lowest: compound 3; then compounds 1 and 2 (each within the scatter of the next).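

In this assay, the ring on the carbonyl carbon can matter a great deal: thiophen-3-yl in place of 1,3-thiazol-5-yl gives a 59-fold lower number from compound 2 to compound 3 (1.77 log units; beyond the scatter), and thiophen-3-yl in place of furan-3-yl gives a 59-fold lower number from compound 1 to compound 3 (1.77 log units; beyond the scatter). The earlier pair alone showed no movement at this place, but compound 3 now shows that swapping one five-membered aromatic ring for another can separate a compound clearly from its close relatives, even with the rest of the structure unchanged. The ring of compound 3 has the same count of heavy atoms as that of compound 2 and differs in carrying one hetero atom rather than two, yet no measurement here explains why this small change in ring atoms goes with such a large step.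

The compounds shown leave open whether other groups on this carbonyl carbon, such as a thiophen-2-yl ring or a phenyl ring, would stay near compound 3 or sit level with compound 1 and compound 2. They also leave open whether the thiophen-3-yl advantage would survive a change elsewhere in the molecule, such as a shorter chain leading to the amide nitrogen.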